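A Dimethoxyphenyl Swap in a Growth Inhibition Series

This account rests on a few compounds, and the source may have more. Where it says the series, first, only, none or still open, it means among the compounds named here.

Of the compounds shown here, three built on a shared core have been measured in a functional assay on A549 cells (Homo sapiens) for inhibition, read by sulforhodamine B assay, with a stated time of 48 h; on this read-out higher numbers stand for weaker inhibition of growth and lower numbers for stronger inhibition of growth. Compound 1 (`COc1ccc(/C=C/C(=O)C(=Cc2ccc(N(C)C)cc2)C(=O)/C=C/c2ccc(OC)c(OC)c2)cc1OC`) gives 2620 nM, compound 2 (`COc1ccc(/C=C/C(=O)C(=Cc2ccc(O)cc2)C(=O)/C=C/c2ccc(OC)c(OC)c2)cc1OC`) gives 420 nM, and compound 3 (`COc1ccc(/C=C/C(=O)C(=Cc2cccc(OC)c2OC)C(=O)/C=C/c2ccc(OC)c(OC)c2)cc1OC`) gives 670 nM. The number for compound 3 stands clear of the highest of the three, with a 3.9-fold lower number from compound 1 to compound 3 (0.59 log units; beyond the scatter). It is not separated from the remaining one, with a 1.6-fold higher number from compound 2 to compound 3 (0.20 log units; within the scatter).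

Compound 4 (`COc1ccc(C=C(C(=O)/C=C/c2ccc(OC)c(OC)c2)C(=O)/C=C/c2ccc(OC)c(OC)c2)c(OC)c1`) has 2,4-dimethoxyphenyl in place of 2,3-dimethoxyphenyl on a double-bonded chain carbon bound to a double-bonded chain carbon. Going by the values given here, no measured step makes this exact swap, so the guide is the other changes at that place. Among the compounds with values here, the one large step there that does not involve compound 3 is a 6.2-fold lower number from compound 1 to compound 2 (0.80 log units; beyond the scatter), and it removes the dimethylamino group, which neither compound 3 nor compound 4 carries. Among the compounds without that group, the only step is small.

In this assay, the expected change is no more than scatter, an estimated 1.1-fold lower number from compound 3 to compound 4 (0.05 log units; within the scatter). Compound 4 is expected at 600 nM, within an estimated range of 250 nM to 1500 nM.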

Compound 4, concentration for 50% growth inhibition: 650 nM
Estimate against measurement, compound 4: 1.1-fold (0.03 log units) below; low and high end bracket the measured number.
By their numbers in this assay, from the lowest: compounds 2, 4 and 3 (each within the scatter of the next); then compound 1.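

In this assay, 2,4-dimethoxyphenyl in place of 2,3-dimethoxyphenyl on a double-bonded chain carbon bound to a double-bonded chain carbon gives a 1.0-fold lower number from compound 3 to compound 4 (0.01 log units; within the scatter), so the two dimethoxyphenyl groups cannot be told apart at this place. The exchange for 4-hydroxyphenyl also shows no separation, with a 1.5-fold higher number from compound 2 to compound 4 (0.19 log units; within the scatter). The exchange for 4-(dimethylamino)phenyl gives a 4.0-fold lower number from compound 1 to compound 4 (0.61 log units; beyond the scatter), which leaves the dimethylamino compound as the only one of the four that stands apart.

No other data on these compounds bear on what lies behind this pattern. From the compounds shown here alone, it remains open whether a carboxylic acid or a nitrile on the aromatic ring at this place would fall with compound 2, compound 3 and compound 4, or with compound 1.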